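This account rests on a few compounds, and the source may have more. Where it says the series, first, only, none or still open, it means among the compounds named here.

Compound 1 `C=C1CCC(c2csc(/C=C(\C)C(N)=O)c2)CC1` in a functional assay on A549 cells (Homo sapiens) for cytotoxicity, read by CCK-8 assay, with a stated time of 24 h (a lower number here means a stronger inhibitor, a higher number a weaker inhibitor), gives > 50000 nM, a limit of the assay rather than a number. Compound 2 `C/C(=C\c1cc(-c2ccccc2)co1)C(N)=O` gives > 50000 nM, likewise a limit. Compound 3 `C/C(=C\c1cc(-c2cccnc2)co1)C(N)=O` gives 6620 nM.

For the measured compounds named here, compound 3 therefore stands alone: its value is the only actual number among the three, while the other two sit at the limit of > 50000 nM in this assay, at which 2 of the 3 values shown sit. Compound 4 `C/C(=C\c1cc(-c2ccc(F)nc2)co1)C(N)=O` has not yet been measured in this assay. It differs from compound 3 by fluoro in place of hydrogen on an aromatic carbon. Going by the values given here, no pair of measured compounds shows what such a swap does here, so the comparison rests on the structural change alone. The change is small, one atom added to a ring without new donors, acceptors or charge, and a step in either direction that stays within the usual scatter seems most likely. Compound 4 is accordingly expected to give about 6000 nM, in a range from 2000 nM to 20000 nM. This estimate means a step of a 1.1-fold lower number from compound 3 to compound 4 (0.04 log units; within the scatter), expected to be no larger than the scatter.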

Compound 4, half-maximal inhibitory concentration: > 50000 nM
Compound 4: no number, only a limit (the forecaster's own chance of this, stated with the estimate: 10%); at least 8.3-fold (0.92 log units) between middle value and limit.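

The position turns out to be sensitive: fluoro in place of hydrogen on an aromatic carbon, next to the ring nitrogen and para to a large group, gives an at least 7.5-fold higher number from compound 3 to compound 4 (0.87 log units; beyond the scatter) in this assay. A single added fluorine atom, with no hydrogen-bond donors or acceptors and no net charge, is therefore enough to remove the only measurable activity among the compounds shown. The value of compound 4, > 50000 nM, is a limit and not a number, so the full size of the step stays unknown, and this limit is a common result in the series: the limit of > 50000 nM in this assay, at which 3 of the 4 values shown sit.

The compounds shown leave open whether this loss is specific to fluoro or would follow from any group placed on this carbon, as only hydrogen and fluoro appear there. A methyl group, a chlorine atom or an amine on the same carbon would help separate these two readings.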